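The source may hold more compounds than are shown below. What is called first, only, known or untested is meant among the compounds shown, and "the series" means these compounds.

Working notes on the series, read in a functional assay on HepG2 cells (Homo sapiens) for antiproliferative activity, read by spectrophotometry, with a stated time of 2 days; a higher number here means a weaker inhibitor of growth, a lower number a stronger inhibitor of growth. Compound 1 `COc1ccc(Nc2ncc(C(F)(F)F)c(N3Cc4cccc(N(C)S(C)(=O)=O)c4C3)n2)cc1C(F)(F)F` gives > 30000 nM, a limit of the assay and not a number. Compound 2 `Cc1ccc(Nc2ncc(C(F)(F)F)c(N3Cc4cccc(N(C)S(C)(=O)=O)c4C3)n2)c(Cl)c1` gives > 30000 nM, again a limit. Compound 3 `Cc1cc(C)cc(Nc2ncc(C(F)(F)F)c(N3Cc4cccc(N(C)S(C)(=O)=O)c4C3)n2)c1` gives > 30000 nM, also a limit, so its place in the series has no number. All three share one ceiling: the limit of > 30000 nM in this assay, at which 3 of the 3 values shown sit.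

Compound 4 `CN(c1cccc2c1CN(c1nc(Nc3cc(Cl)cc(C(F)(F)F)c3)ncc1C(F)(F)F)C2)S(C)(=O)=O` carries 3-chloro-5-(trifluoromethyl)phenyl in place of 3,5-dimethylphenyl on a nitrogen on an aromatic ring.

The measured steps that bear on this change the group at that same place. They are a step that the two limits leave unreadable from compound 1 to compound 2, a step that the two limits leave unreadable from compound 1 to compound 3 and a step that the two limits leave unreadable from compound 2 to compound 3. None of them therefore offers a size to carry over.

Compound 3 stands at > 30000 nM, a limit, and no step beyond the scatter is expected in this assay. The expected result is that the new group leaves the reading at or near the ceiling.

The estimated step is a number no higher from compound 3 to compound 4 (the limit leaves the size open). The estimate for compound 4 is 30000 nM, with an expected range of 10000 nM to 60000 nM.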

Compound 4, concentration for 50% growth inhibition: 9900 nM
Compound 4: the middle estimate sits 3.0-fold (0.48 log units) above what was measured; measured number outside the range, below it.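

In this assay compound 4 gives 9900 nM, the only reading shown that is a number and not a limit, so the aryl group on this nitrogen can give the series a measurable reading. The change reads as an at least 3.0-fold lower number from compound 3 to compound 4 (0.48 log units; beyond the scatter), as an at least 3.0-fold lower number from compound 2 to compound 4 (0.48 log units; beyond the scatter) and as an at least 3.0-fold lower number from compound 1 to compound 4 (0.48 log units; beyond the scatter). These sizes stay open-ended and the steps among compound 1, compound 2 and compound 3 cannot be read, because those three compounds stand at the shared ceiling: the limit of > 30000 nM in this assay, at which 3 of the 4 values shown sit.

Going by these compounds, compound 4 differs from compound 3 in both ring groups, so it remains open whether the chloro or the trifluoromethyl group carries the step. On these data alone, a nitrile or a carboxylic acid on that phenyl ring also remains open.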